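Hydroxyalkyl amino chain: from compound 2 to compound 3

A few compounds are considered here, and "the series" means these few. Any claim that something is new, unique, unknown or untested is made for them only; others in the source may bear on it.

In a functional assay on CH1 cells (Homo sapiens) for inhibition, read by sulforhodamine B assay, with a stated time of 96 h (a higher number here means a weaker inhibitor of growth, a lower number a stronger inhibitor of growth), compound 1 `CCC(O)[C@@H](CC)Nc1nc(NCc2ccccn2)c2ncn(C(C)C)c2n1` reads 26000 nM for growth inhibition, and compound 2 `CC[C@@H](Nc1nc(NCc2ccccn2)c2ncn(C(C)C)c2n1)C(O)C(C)(C)C` reads 27000 nM on the same scale, so the two stand level within the scatter. Compound 3 `CC[C@H](Nc1nc(NCc2ccccn2)c2ncn(C(C)C)c2n1)C(C)O` keeps the shared core and alters only the chain, with 1-(1-hydroxyethyl)propyl in place of 1-ethyl-2-hydroxy-3,3-dimethylbutyl on a nitrogen on an aromatic ring is the counted difference. For the measured compounds named here, one measured step bears on this, a 1.0-fold higher number from compound 1 to compound 2 (0.02 log units; within the scatter) in size, where tert-butyl in place of ethyl left the number within the scatter. With so large a change in that chain showing no effect, no shift beyond the scatter is expected in this assay here, in either direction. The expected step is a 1.0-fold lower number from compound 2 to compound 3 (0.02 log units; within the scatter) in size. For compound 3 the estimate is 26000 nM as the expected value, with 12000 nM to 55000 nM as its expected range.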

Compound 3, concentration for 50% growth inhibition: 15500 nM
For compound 3 the middle estimate is 1.7-fold (0.22 log units) above the measured one, within the range that was stated.
By their numbers in this assay, from the lowest: compounds 3, 1 and 2 (each within the scatter of the next).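

In this assay, 1-(1-hydroxyethyl)propyl in place of 1-ethyl-2-hydroxy-3,3-dimethylbutyl gives a 1.7-fold lower number from compound 2 to compound 3 (0.24 log units; within the scatter) and stays within the scatter, as does the same group in place of 1-ethyl-2-hydroxybutyl, with a 1.7-fold lower number from compound 1 to compound 3 (0.22 log units; within the scatter) as its step. The position on the nitrogen on an aromatic ring therefore now holds three hydroxyl-bearing chains, and the 6 heavy atoms of 1-(1-hydroxyethyl)propyl read level with the 9 of 1-ethyl-2-hydroxy-3,3-dimethylbutyl. Nothing at hand accounts for this flat reading.

All three compounds carry a hydroxyl on this chain, so the compounds shown do not tell whether the hydroxyl itself matters at this position. As far as these compounds go, an amine or a carboxylic acid in its place, or a plain alkyl chain with no oxygen, remains open, as does any change elsewhere on the shared core.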